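A few compounds are considered here, and "the series" means these few. Any claim that something is new, unique, unknown or untested is made for them only; others in the source may bear on it.

Measured in an ADME assay on microsomes from liver (Homo sapiens) for metabolic stability, with a stated time of 10 min; a lower number here means that less of the compound is left, a higher number that more of the compound is left:
- compound 1 `COc1ccccc1-n1nc([C@H]2C[C@@H](C)O[C@@H](C)C2)cc1-c1ccc(Cl)cc1`: 64%
- compound 2 `COCCCc1cc(-c2ccc(Cl)cc2)n(-c2ccccc2OC)n1`: 58%
- compound 3 `COc1ccccc1-n1nc(C2C[C@H](C)O[C@@H](C)C2)cc1-c1ccc(Cl)cc1`: 40%

In this assay, compound 3 is the lowest of the three at 40%, and its gaps to both others are beyond the scatter. The next structure is compound 4 `COc1ccccc1-n1nc([C@@H]2CCO[C@H](C(C)C)C2)cc1-c1ccc(Cl)cc1`, with 2-isopropyloxan-4-yl in place of 2,6-dimethyloxan-4-yl on an aromatic carbon.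

For the measured compounds named here, no measured step makes this exchange. The nearest evidence at the same place is a number 18 percentage points lower from compound 2 to compound 3 (beyond the scatter), while a number 6 percentage points lower from compound 1 to compound 2 (within the scatter). The largest step is a number 24 percentage points lower from compound 1 to compound 3 (beyond the scatter), and it comes with the fact that one of compounds 1 and 3 is drawn with a defined configuration and the other without, at the place where they differ. Since both oxane groups in the exchange are close in kind, no step beyond the scatter is expected in this assay. The expected change is a number 2 percentage points higher from compound 3 to compound 4 (within the scatter). The range stays wide because a number 24 percentage points lower from compound 1 to compound 3 (beyond the scatter) spans a sizeable gap without any change of atoms or bonds. For compound 4 the estimated value is 42%, with an expected range of 22% to 64%.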

Compound 4, percent of the compound remaining: 66%
Compound 4: middle estimate off by 24 percentage points, on the low side; the whole stated range lies below it.
By their numbers in this assay, from the lowest: compound 3; then compounds 2, 1 and 4 (each within the scatter of the next).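

In this assay, 2-isopropyloxan-4-yl in place of 2,6-dimethyloxan-4-yl gives two different readings depending on the partner: a number 26 percentage points higher from compound 3 to compound 4 (beyond the scatter), whereas a number 2 percentage points higher from compound 1 to compound 4 (within the scatter). Against the open chain, a number 8 percentage points higher from compound 2 to compound 4 (within the scatter), so this aromatic carbon accepts the oxane with the isopropyl group and 3-methoxypropyl with no difference beyond the scatter. The exchange therefore has no single size of its own, and the low number of compound 3 is better tied to how its oxane is drawn than to the 2,6-dimethyl pattern as such, because compound 1 carries the same group: the fact that one of compounds 1 and 3 is drawn with a defined configuration and the other without, at the place where they differ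

Still open, from the compounds shown here alone, is how much configuration counts for 2-isopropyloxan-4-yl, as only one drawn form stands. Also open, going by these compounds, is how a piperidin-4-yl amine or a carboxylic acid on this aromatic carbon would read in this assay.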